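Trifluoromethoxy in Place of Methyl on a P2X7 Antagonist

The source may report more compounds than this note shows. Statements on the series, on what has been measured and on what is new or still open speak of the compounds shown alone.

Measured so far:
compound 1, `Cc1ccccc1Nc1ncnn1-c1cccc(Cl)c1Cl`: 17.8 nM
compound 2, `CCc1ccccc1Nc1ncnn1-c1cccc(Cl)c1Cl`: 45.7 nM

In a functional assay for antagonist activity at P2X purinoceptor 7 (Homo sapiens), read by FLIPR and calcium flux (a higher number here means a weaker inhibitor, a lower number a stronger inhibitor), compound 1 gives 17.8 nM, the lowest of the two numbers recorded so far. Its nearest neighbour is compound 2, which gives 45.7 nM. For the measured compounds named here, the one measured step between them is a 2.6-fold higher number from compound 1 to compound 2 (0.41 log units; beyond the scatter); it is modest, yet it exceeds the usual scatter of repeated runs.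

Compound 3, `FC(F)(F)Oc1ccccc1Nc1ncnn1-c1cccc(Cl)c1Cl`, has not been measured. It differs from compound 1 in one place only: trifluoromethoxy in place of methyl on an aromatic carbon. Going by the values given here, the measured step that bears on this is the one from compound 1 to compound 2, as it alters the very same methyl. Among the compounds with values here, that step, a 2.6-fold higher number from compound 1 to compound 2 (0.41 log units; beyond the scatter), is the only guidance available, and it points upward. A single step cannot show whether every alteration of this methyl weakens inhibition, but with nothing pointing the other way, a modest rise of similar size is the expectation. The estimate therefore amounts to a 2.2-fold higher number from compound 1 to compound 3 (0.35 log units; beyond the scatter). For compound 3 the expected value is 40 nM, with a likely range from 15 nM to 120 nM.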

Compound 3, half-maximal inhibitory concentration: 617 nM
For compound 3 the middle estimate is 15-fold (1.19 log units) below the measured one; measured number outside the range, above it.
By their numbers in this assay, from the lowest: compound 1; then compound 2; then compound 3.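

This position is far less forgiving than the first pair suggested. In this assay, trifluoromethoxy in place of methyl gives a 35-fold higher number from compound 1 to compound 3 (1.54 log units; beyond the scatter) and counts as a large step, while ethyl in place of that methyl gave only the modest 2.6-fold higher number from compound 1 to compound 2 (0.41 log units; beyond the scatter) in the same test. Trifluoromethoxy also compares poorly with ethyl, with a 14-fold higher number from compound 2 to compound 3 (1.13 log units; beyond the scatter) on that swap, so the loss is not seen against methyl alone, and the data offer no measurement that would explain it.

Trifluoromethoxy brings an oxygen and three fluorines together, so these compounds cannot separate what each part contributes; methoxy, which has the oxygen without the fluorines, and trifluoromethyl, which has the fluorines without the oxygen, would be the closest groups to compare. Also open, going by these compounds, is how a simple chlorine or an amine would behave on this same aromatic carbon, ortho to a large group, since three compounds give only a thin picture of what this place in the shared core will accept.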